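Swapping Benzyl for tert-Butyl on a Fluorinated Nitrone

A few compounds are considered here, and "the series" means these few. Any claim that something is new, unique, unknown or untested is made for them only; others in the source may bear on it.

Compound 1, `[O-]/[N+](=C\c1cn(CCC(F)(F)C(F)(F)C(F)(F)C(F)(F)C(F)(F)C(F)(F)F)nn1)Cc1ccccc1`, was tested in a functional assay on COLO 205 cells (Homo sapiens) for inhibition, read by MTT assay, with a stated time of 24 h; a higher number here means a weaker inhibitor, a lower number a stronger inhibitor. There compound 1 reaches only the limit of the assay, reported as > 100000 nM, which is not a number. Its longer-chain relative, compound 2, `[O-]/[N+](=C\c1cn(CCC(F)(F)C(F)(F)C(F)(F)C(F)(F)C(F)(F)C(F)(F)C(F)(F)C(F)(F)F)nn1)Cc1ccccc1`, gives 9400 nM in this assay. Among the measured compounds shown here, the measured step of an at least 10-fold lower number from compound 1 to compound 2 (1.02 log units; beyond the scatter) is the only single-point change in this set, and it lies on the fluorinated chain rather than on the nitrone; since compound 1 sits at the limit of > 100000 nM in this assay, at which 1 of the 3 values shown sits, that step is known only as a bound. For the measured compounds named here, a third compound, compound 3, `COc1ccc(-n2cc(/C=[N+](\[O-])C(C)(C)C)nn2)cc1`, carries a tert-butyl group on the nitrone nitrogen and gives 19800 nM in this assay, but it differs from compound 1 in more than one place, so no single step links them.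

Compound 4, `CC(C)(C)/[N+]([O-])=C/c1cn(CCC(F)(F)C(F)(F)C(F)(F)C(F)(F)C(F)(F)C(F)(F)F)nn1`, differs from compound 1 by tert-butyl in place of benzyl on a double-bonded nitrogen. Going by the values given here, no measured step in this set bears on that change, and compound 1 itself offers only a limit, so the expectation rests on little. Compound 4 is therefore estimated to give 60000 nM in this assay, between 15000 nM and 250000 nM, with a real chance of returning only a limit again. This corresponds to an expected step of an at least 1.6-fold lower number from compound 1 to compound 4 (0.22 log units; that floor lies within the scatter).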

Compound 4, half-maximal inhibitory concentration: 9500 nM
Beside the measured number, compound 4's estimate is 6.3-fold (0.80 log units) above it, and the stated range ends above it.
By their numbers in this assay, from the lowest: compounds 2 and 4 (each within the scatter of the next); then compound 3. At a limit, above all of these: compound 1.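

Among the compounds shown here, the nitrone nitrogen, on which no earlier pair offered a single-point comparison, now has one: in this assay, tert-butyl in place of benzyl on a double-bonded nitrogen gives an at least 10-fold lower number from compound 1 to compound 4 (1.02 log units; beyond the scatter). With the fluorinated chain kept as in compound 1, this shows that the read-out responds to the group at this position and not only to the chain, and that, in this pair, the benzyl group and its aromatic ring are not required for a measurable value. The step can be stated only as a bound because compound 1 stands at a limit and not at a number: the limit of > 100000 nM in this assay, at which 1 of the 4 values shown sits.

On these data alone, what the same exchange would do on the longer fluorinated chain of compound 2 remains open. Also open, as far as these compounds go, is how far the response at this position extends to other groups on the nitrogen, such as a methyl or a cyclohexyl group, and whether it depends on the size of the group or on the loss of the aromatic ring.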